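The source may hold more compounds than are shown below. What is called first, only, known or untested is meant among the compounds shown, and "the series" means these compounds.

Of the compounds shown here, three sharing one core have been measured in a functional assay on MCF7 cells (Homo sapiens) for inhibition, read by MTT assay, with a stated time of 72 h; on this read-out higher numbers stand for weaker inhibition and lower numbers for stronger inhibition. Compound 1 `COc1ccc(Nc2nc(Oc3cccc(NC(=O)C=C(C)C)c3)c3sccc3n2)cc1` gives 46100 nM. Compound 2 `C=CC(=O)Nc1cccc(Oc2nc(Nc3cccc(OC)c3)nc3ccsc23)c1` gives 19000 nM, and compound 3 `C/C=C/C(=O)Nc1cccc(Oc2nc(Nc3cccc(OC)c3)nc3ccsc23)c1` gives 14600 nM, the lowest of the three numbers. The step of a 1.3-fold lower number from compound 2 to compound 3 (0.11 log units; within the scatter) lies within the scatter, whereas compound 1 stands beyond the scatter above compound 3.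

Compound 4 `COc1cccc(Nc2nc(Oc3cccc(NC(=O)C=C(C)C)c3)c3sccc3n2)c1` has not yet been measured. It differs from compound 3 in one place: 2-methylprop-1-en-1-yl in place of prop-1-en-1-yl on a carbonyl carbon. Among the measured compounds shown here, the only measured step that touches this same carbonyl chain is the one from compound 2 to compound 3, and it was small, so a further change to that chain is expected to shift the number only modestly. Compound 1, which carries the same 2-methylprop-1-en-1-yl group but is not otherwise identical to compound 4, gives a higher number than compound 3, which leaves some room for a weaker result. Compound 4 is therefore expected to show a 1.5-fold higher number from compound 3 to compound 4 (0.18 log units; within the scatter) in this assay. The estimated value of compound 4 is 22000 nM, with a range from 9000 nM to 55000 nM.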

Compound 4, half-maximal inhibitory concentration: 35800 nM
For compound 4 the middle estimate is 1.6-fold (0.21 log units) below the measured one; the measured number falls inside the stated range.
By their numbers in this assay, from the lowest: compounds 3, 2, 4 and 1 (each within the scatter of the next, the first and the last beyond it).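

On the carbonyl carbon, 2-methylprop-1-en-1-yl in place of prop-1-en-1-yl gives a 2.5-fold higher number from compound 3 to compound 4 (0.39 log units; beyond the scatter) in this assay, so this chain can shift the number beyond the scatter, which the earlier step of a 1.3-fold lower number from compound 2 to compound 3 (0.11 log units; within the scatter) did not show. Measured against the vinyl group, however, the same chain gives a 1.9-fold higher number from compound 2 to compound 4 (0.28 log units; within the scatter), so compound 2 and compound 4 cannot be told apart, and only the comparison with compound 3 stands out. The other end of the molecule can now be read as well: 3-methoxyphenyl in place of 4-methoxyphenyl on a nitrogen on an aromatic ring gives a 1.3-fold lower number from compound 1 to compound 4 (0.11 log units; within the scatter), a change that stays within the scatter.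

Still open, going by these compounds, is how a saturated propyl chain, a longer chain or an added amine on this carbonyl carbon would read. No available measurement addresses what lies behind the step from prop-1-en-1-yl to 2-methylprop-1-en-1-yl.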